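Shortening the amide substituent in a sirtuin-6 series

A few compounds are considered here, and "the series" means these few. Any claim that something is new, unique, unknown or untested is made for them only; others in the source may bear on it.

Measured so far:
compound 1 `CCCCNC(=O)CCCSC[C@H](NC(=O)OCc1ccccc1)C(=O)Nc1ccccc1` — 26%
compound 2 `CCNC(=O)CCCSC[C@H](NC(=O)OCc1ccccc1)C(=O)Nc1ccccc1` — 15%
compound 3 `O=C(O)CNC(=O)CCCSC[C@H](NC(=O)OCc1ccccc1)C(=O)Nc1ccccc1` — 53%

Of the compounds shown here, three sharing one core have been tested in an assay for inhibition of NAD-dependent protein deacylase sirtuin-6 (Homo sapiens), read by HPLC, with stated times of 15 min and 1 h, tested at 333 uM; a higher number here means more inhibition at the concentration tested (going by the name of the read-out), a lower number less inhibition. Compound 1 stands second highest of the three: compound 2 lies below it, by a number 11 percentage points lower from compound 1 to compound 2 (beyond the scatter), while compound 3 lies above it, by a number 27 percentage points higher from compound 1 to compound 3 (beyond the scatter). Between the two smaller amides, compound 3 also stands above compound 2, by a number 38 percentage points higher from compound 2 to compound 3 (beyond the scatter).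

Compound 4 `CNC(=O)CCCSC[C@H](NC(=O)OCc1ccccc1)C(=O)Nc1ccccc1` has not yet been measured. It differs from compound 1 as follows: hydrogen in place of propyl on a saturated chain carbon bound to an amide-type nitrogen. Among the compounds with values here, the step that bears on this change is the one from compound 1 to compound 2, a number 11 percentage points lower from compound 1 to compound 2 (beyond the scatter), where the substituent was likewise cut back and the number fell modestly. The steps toward compound 3 involve a carboxy group and do not apply here. Compound 4 is therefore expected to fall by about a number 14 percentage points lower from compound 1 to compound 4 (beyond the scatter) relative to compound 1, reaching an estimated 12% in this assay, within a range from 2% to 24%.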

Compound 4, a percentage reported as inhibition, at one concentration (the size of the read-out at that concentration, not a potency): "not active" (no number reported)
Compound 4 has no reported number here; no gap can be computed for the estimate.
By their numbers in this assay, from the lowest: compound 2; then compound 1; then compound 3.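

Within the data shown here, compound 4 is reported as "not active" with no number, so no step linking it to compound 1, compound 2 or compound 3 can be read. No evidence on hand accounts for this result. The compounds shown leave open where methylcarbamoyl stands numerically relative to butylcarbamoyl.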